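Capping the phenol: from compound 3 to compound 4

The compounds below may be only part of what the source reports. "The series", "measured", "known", "first", "only" and "open" are said of these compounds alone.

Of the compounds shown here, three sharing a furan-linked acylhydrazone core have been measured in a functional assay on Bel-7402 cells (Homo sapiens) for inhibition, read by sulforhodamine B assay, with a stated time of 48 h, tested at 10 uM; a lower number here means less inhibition of growth, a higher number more inhibition of growth at the concentration tested. Compound 1 `O=C(N/N=C/c1ccccc1O)c1ccc(-c2ccc(F)cc2)o1` gives 40% in this assay, while compound 2 `O=C(N/N=C/c1ccccc1)c1ccc(-c2ccc(Cl)cc2)o1` gives 2.28%. Compound 3 `O=C(N/N=C/c1ccc(-c2ccc(F)cc2F)o1)c1ccccc1O` stands highest of the three with 63.4% in this assay, a gap beyond the scatter to both compound 1 and compound 2.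

Compound 4 `COc1ccccc1C(=O)N/N=C/c1ccc(-c2ccc(F)cc2F)o1` differs from compound 3 in one place: methyl in place of hydrogen on an oxygen on an aromatic ring. Among the compounds with values here, no measured pair shows this particular change, so its size can only be guessed. Within the data shown here, compound 2, the only compound here without a hydroxy group, gives 2.28%, which hints that a free hydroxy may matter, although its position differs from that in compound 3. A drop beyond the scatter in this assay is therefore expected, with a number 28.4 percentage points lower from compound 3 to compound 4 (beyond the scatter) as the estimated step. Compound 4 is expected to give 35% in this assay, within a range from 5% to 65%.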

Compound 4, percent growth inhibition at one concentration: 1.69%
Compound 4: the middle estimate sits 33.3 percentage points above what was measured; measured number below the stated range.
By their numbers in this assay, from the lowest: compounds 4 and 2 (each within the scatter of the next); then compound 1; then compound 3.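

In this assay, within the data shown here, hydroxy to methoxy on the aromatic ring gives a number 61.7 percentage points lower from compound 3 to compound 4 (beyond the scatter), the first step here that isolates this position. A single methyl on that oxygen removes nearly all of the growth inhibition seen at the tested concentration, so compound 4 gives only 1.69%. The compounds therefore show that this hydroxy cannot take a methyl cap in this series without a large loss, but no measurement at hand explains why the loss occurs.

It remains open whether an amine, a fluorine or an ethoxy in place of the hydroxy would retain any of the inhibition shown by compound 3. It is also unknown whether the same methyl cap would cost as much on compound 1, whose hydroxy stands elsewhere in the molecule.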